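The compounds below may be only part of what the source reports. "The series", "measured", "known", "first", "only" and "open" are said of these compounds alone.

compound 1 `Cc1cc(C)cc(S(=O)(=O)n2c(SCC(=O)Nc3ccccc3S(N)(=O)=O)nc3ccccc32)c1`: 25000 nM
compound 2 `COC(=O)c1ccc(NC(=O)COc2nc3ccccc3n2S(=O)(=O)c2cc(C)cc(C)c2)c(Cl)c1`: 119000 nM

In an ADME assay on MT4 cells (Homo sapiens) for cytotoxicity, read by MTT assay, with a stated time of 5 days (a higher number here means that more compound is tolerated, a lower number that less compound is tolerated), compound 2 sits above compound 1, which at 25000 nM is the lower of the two numbers, and the gap lies beyond the usual scatter. The next compound to be tested is compound 3 `COC(=O)c1ccc(NC(=O)CSc2nc3ccccc3n2S(=O)(=O)c2cc(C)cc(C)c2)c(Cl)c1`. Its difference from compound 1 is 2-chloro-4-(methoxycarbonyl)phenyl in place of 2-sulfamoylphenyl on an amide-type nitrogen. Among the compounds with values here, the only measured compound carrying the entering 2-chloro-4-(methoxycarbonyl)phenyl is compound 2 at 119000 nM and this single value is the reason for expecting an upward move. With so little data, only part of that gap is assumed to carry over. In this assay the expected step, likely beyond the scatter, is a 2.4-fold higher number from compound 1 to compound 3 (0.38 log units; beyond the scatter) and more compound should be tolerated. In this assay compound 3 is estimated at 60000 nM with an expected range of 22000 nM to 150000 nM as the working figure.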

Compound 3, half-maximal cytotoxic concentration: 145000 nM
Compound 3: the middle estimate sits 2.4-fold (0.38 log units) below what was measured; low and high end bracket the measured number.
By their numbers in this assay, from the lowest: compound 1; then compounds 2 and 3 (each within the scatter of the next).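

In this assay, the swap of 2-sulfamoylphenyl for 2-chloro-4-(methoxycarbonyl)phenyl on an amide-type nitrogen gives a 5.8-fold higher number from compound 1 to compound 3 (0.76 log units; beyond the scatter), so a change at this position alone moves the number beyond the scatter, which the multi-site difference between compounds 1 and 2 could not show. Compound 3 at 145000 nM and compound 2 at 119000 nM lie within the scatter of each other, so both compounds carrying the entering group have numbers well clear of that of compound 1. No supporting data bear on the origin of this step.

Still open, as far as these compounds go, is which part of the exchange carries the step: the chlorine, the methoxycarbonyl or the loss of the sulfamoyl group. A plain phenyl, or a carboxylic acid in place of the methoxycarbonyl, would help separate these, and one pair sets no general trend.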